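A few compounds are considered here, and "the series" means these few. Any claim that something is new, unique, unknown or untested is made for them only; others in the source may bear on it.

Compound 1 `Cc1c2c(n3c1CCCN[C@@H](C)[C@H](C)Nc1cc-3ccc1C(N)=O)CC(C)(C)CC2=O`: 61 nM
Compound 2 `CC(=O)N1CCc2c(C)c3c(n2-c2ccc(C(N)=O)c(c2)N[C@@H](C)[C@H](C)C1)CC(C)(C)CC3=O`: 24 nM
Compound 3 `COCCC(=O)N1CCc2c(C)c3c(n2-c2ccc(C(N)=O)c(c2)N[C@@H](C)[C@H](C)C1)CC(C)(C)CC3=O`: 54 nM

These numbers come from a functional assay on U-87MG ATCC cells (Homo sapiens) for antiproliferative activity; on this read-out higher numbers stand for weaker inhibition and lower numbers for stronger inhibition. Compound 3 stands with compound 1 at the upper end of this small set, the two lying within the usual scatter of each other. Compound 4 `Cc1c2c(n3c1CCN(C(=O)C1(N)CC1)C[C@@H](C)[C@H](C)Nc1cc-3ccc1C(N)=O)CC(C)(C)CC2=O` has 1-aminocyclopropyl in place of 2-methoxyethyl on a carbonyl carbon. For the measured compounds named here, the only measured step that touches this group is a 2.3-fold higher number from compound 2 to compound 3 (0.35 log units; beyond the scatter), where methoxymethyl replaced hydrogen on a saturated chain carbon bound to a carbonyl carbon. That step was modest, which suggests that this group can change without a large shift in the number. Going by the values given here, it is only one step, though, and no measured compound has a ring or an amino group here, so the direction remains uncertain. A small move towards a lower number is expected, with no change beyond the scatter. In this assay the estimated step is a 1.4-fold lower number from compound 3 to compound 4 (0.15 log units; within the scatter). Compound 4 is estimated at 38 nM, with an expected range from 12 nM to 120 nM.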

Compound 4, half-maximal inhibitory concentration: 85 nM
Compound 4: middle estimate off by 2.2-fold (0.35 log units), on the low side, within the range that was stated.
By their numbers in this assay, from the lowest: compound 2; then compounds 3, 1 and 4 (each within the scatter of the next).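

In this assay, 1-aminocyclopropyl in place of 2-methoxyethyl on the carbonyl carbon gives a 1.6-fold higher number from compound 3 to compound 4 (0.20 log units; within the scatter), so bringing in a three-membered ring and an amine at this position does not move the number beyond the usual scatter of the ether chain. Against the small methyl group, the same 1-aminocyclopropyl gives a 3.5-fold higher number from compound 2 to compound 4 (0.55 log units; beyond the scatter), and with the earlier step from methyl to 2-methoxyethyl, both replacements of methyl shown here end at a higher number. Nothing available explains why methyl gives the lower number.

Still open, from the compounds shown here alone, is whether the ring or the amine matters for the step from methyl, which plain cyclopropyl or an open-chain aminomethyl group would help to separate.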